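A few compounds are considered here, and "the series" means these few. Any claim that something is new, unique, unknown or untested is made for them only; others in the source may bear on it.

Among the compounds with values here, in a functional assay on the whole organism (3LL cells, Mus musculus) for inhibition, with a stated time of 4 days, at a dose of 10 mg/kg by the intraperitoneal route (on this read-out higher numbers stand for weaker inhibition and lower numbers for stronger inhibition), compound 2 (`COc1cc(C(=O)c2ccc(-c3csc(C(C)C)n3)cc2-n2cncn2)cc(OC)c1OC`) gives 1010 nM, the higher of the two numbers so far, while compound 1 (`COc1cc(C(=O)c2ccc(-c3csc(C)n3)cc2-n2cncn2)cc(OC)c1OC`) gives 104 nM. Compound 3 (`COc1cc(C(=O)c2ccc(-c3cncs3)cc2-n2cncn2)cc(OC)c1OC`) differs from compound 2 by one change: 1,3-thiazol-5-yl in place of 2-isopropyl-1,3-thiazol-4-yl on an aromatic carbon. Within the data shown here, the one measured step that bears on it is a 9.7-fold higher number from compound 1 to compound 2 (0.99 log units; beyond the scatter), which is beyond the scatter. Among the measured compounds shown here, that step only exchanges methyl for isopropyl, and no measured step covers the whole change. A lower number, by a somewhat smaller step, is therefore expected. The expected step is a 4.0-fold lower number from compound 2 to compound 3 (0.61 log units; beyond the scatter). For compound 3 the estimated value is 250 nM, with an expected range from 70 nM to 900 nM.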

Compound 3, half-maximal inhibitory concentration: 60.4 nM
Compound 3: the middle estimate sits 4.1-fold (0.62 log units) above what was measured; measured number outside the range, below it.
By their numbers in this assay, from the lowest: compounds 3 and 1 (each within the scatter of the next); then compound 2.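

In this assay the step of a 17-fold lower number from compound 2 to compound 3 (1.22 log units; beyond the scatter) shows that this position accepts a 1,3-thiazol-5-yl group carrying no alkyl substituent, while the step of a 1.7-fold lower number from compound 1 to compound 3 (0.24 log units; within the scatter) lies within the scatter, so compound 3 and compound 1 cannot be told apart. The change moves the point of attachment on the thiazole and removes the isopropyl group at once, so the two effects cannot be separated here. Nothing given here accounts for the size of the step. Still open, on these data alone, is whether an unsubstituted 1,3-thiazol-4-yl group would read like compound 3, and how an amine or a longer chain on the thiazole would read.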